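The compounds below may be only part of what the source reports. "The series", "measured", "known", "first", "only" and "open" are said of these compounds alone.

Notes on a small set of aryl-ether esters tested for binding to P-selectin.

Compound 1, `CCCCCCCCCCOc1cccc(OCCCCCCON=C(c2ccc(C(=O)O)cc2)c2ccc(C(=O)O)cc2)c1`, has no result reported in an assay on isolated protein for binding affinity to P-selectin (Homo sapiens), read by ELISA, tested at 500 uM; on this read-out lower numbers stand for less inhibition and higher numbers for more inhibition at the one concentration tested (going by the name of the read-out): for compound 1 the entry reads "not determined" (no result reported). Compound 3, `CCCCCCCCCCOc1cc(OCCCCCCCCCC)cc(OCCCCCCN(Cc2ccc(C(=O)OC)cc2)c2ccc(C(=O)OC)cc2)c1`, likewise has no number reported in this assay: for compound 3 the entry reads "not determined" (no result reported). Within the data shown here, the one measured member is compound 2, `CCCCCCCCCCOc1cc(OCCCCCCCCCC)cc(OCCCCCC(=O)N(c2ccc(C(=O)OC)cc2)c2ccc(C(=O)OC)cc2)c1`, and in this assay compound 2 gives 16%. Since no other number is shown, compound 2 stands alone: its inhibition at the single concentration is modest, and nothing in the set places it above or below any companion.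

Compound 4, `CCCCCCCCCCOc1cc(OCCCCCCCCCC)cc(OCCCCCC(=O)N(c2ccc(C(=O)OC)cc2)c2ccc(C(=O)OC)c(C(=O)OC)c2)c1`, is the next entry to be measured. It differs from compound 2 by one counted change, (methoxycarbonyl in place of hydrogen on an aromatic carbon), the new group sitting on an aromatic carbon of a six-membered aromatic ring of carbon only, ortho to a methoxycarbonyl group and meta to a large group. Among the measured compounds shown here, no measured pair in the set shows what such a change does, so the expected step can rest only on the value of compound 2.

The expectation is a step from compound 2 to compound 4 of a number 2 percentage points higher from compound 2 to compound 4 (within the scatter), that is, no movement beyond the usual scatter in either direction. Compound 4 is therefore estimated to give 18% in this assay, with a plausible range from 5% to 35%.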

Compound 4, a percentage reported as inhibition, at one concentration (the size of the read-out at that concentration, not a potency): 90%
Compound 4: the middle estimate sits 72 percentage points below what was measured; the measured number lies above the stated range.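

Among these compounds, the change of methoxycarbonyl in place of hydrogen on an aromatic carbon, ortho to a methoxycarbonyl group and meta to a large group, comes with a number 74 percentage points higher from compound 2 to compound 4 (beyond the scatter) in this assay, the first step that can be read. The earlier compounds shown here offered a single number and no pair, so they could not show that this aromatic carbon matters for the read-out; with this one change, compound 4 reaches 90% at the one concentration tested, a size of inhibition and not a potency. No measurement accompanying these compounds bears on the reason for the step, which therefore stands as an observation from one pair.

Whether the step depends on methoxycarbonyl itself remains open, as the compounds shown do not include a carboxylic acid, a nitrile or an amine on the same aromatic carbon. Also open, going by these compounds, is whether the same change would carry over to the cores of compound 1 and compound 3 , whose entries offer no number for comparison.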